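Swapping One Halogen-Bearing Ring for Another

The source may report more compounds than this note shows. Statements on the series, on what has been measured and on what is new or still open speak of the compounds shown alone.

Compound 2 `CC(/C=N/Nc1ccc([N+](=O)[O-])cc1)=N\NC(=O)c1ccc(Cl)cc1` was tested in a functional assay on cells (Splenocyte, Mus musculus, strain BALB/c) for inhibition, read by scintillation counting and thymidine incorporation, with a stated time of 72 h (a higher number here means a weaker inhibitor, a lower number a stronger inhibitor), where compound 2 gives 4200 nM. Of the two plain numbers this is the higher; compound 1 `CC(/C=N/N(C)c1ccc([N+](=O)[O-])cc1)=N\NC(=O)c1cc([N+](=O)[O-])cc([N+](=O)[O-])c1` gives 1110 nM. Compound 3 `CC(/C=N/Nc1ccc([N+](=O)[O-])cc1)=N\NC(=O)c1ccc(C(C)(C)C)cc1` reaches only a limit of the assay, > 12000 nM, as recorded at the limit of > 12000 nM in this assay, at which 1 of the 3 values shown sits. Compound 4 `CC(/C=N/Nc1ccc([N+](=O)[O-])cc1)=N\NC(=O)c1ccccc1F` differs from compound 2 in one place: 2-fluorophenyl in place of 4-chlorophenyl on a carbonyl carbon. Within the data shown here, the one step that bears on this change is an at least 2.8-fold higher number from compound 2 to compound 3 (0.45 log units; beyond the scatter), which exchanged the group on the same carbonyl carbon and weakened inhibition. The entering group here is different, and a rise of that size need not recur; a modest rise at most, or none beyond the scatter, is expected. Compound 4 is therefore estimated at 5000 nM, likely between 1800 nM and 14000 nM. The expected step is a 1.2-fold higher number from compound 2 to compound 4 (0.08 log units; within the scatter).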

Compound 4, half-maximal inhibitory concentration: > 12000 nM
Compound 4: a limit, no number; the forecaster's own chance of this, stated with the estimate: 20%; middle value at least 2.4-fold (0.38 log units) away from the limit.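

Compound 3 had suggested that this carbonyl carbon tolerates change poorly, and this second, quite different exchange points the same way: 2-fluorophenyl in place of 4-chlorophenyl gives an at least 2.8-fold higher number from compound 2 to compound 4 (0.45 log units; beyond the scatter) in this assay. Among the compounds shown, 4-chlorophenyl is thus the only group here with a plain number. Compound 4, like compound 3, stands at a limit, not a number: the limit of > 12000 nM in this assay, at which 2 of the 4 values shown sit.

As far as these compounds go, whether the change of halogen or its new place on the ring matters more stays open. A 4-fluorophenyl or 2-chlorophenyl group on the same carbonyl carbon would separate the two.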